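The compounds below may be only part of what the source reports. "The series", "measured", "known", "first", "only" and "open" are said of these compounds alone.

Compound 1, `Cc1ccc(NS(=O)(=O)c2ccc3c(c2)C(=O)CC(C2CCOCC2)O3)c(C)c1`: 2.75
Compound 2, `CC(C)CN(c1ccc(F)cc1F)S(=O)(=O)c1ccc2c(c1)C(=O)CC(C1CCOCC1)O2`: 3.62
Compound 3, `O=C1CC(C2CCOCC2)Oc2ccc(S(=O)(=O)N3CCCC3c3ccccc3C(F)(F)F)cc21`: 3.5

In a physicochemical assay for lipophilicity, at pH 7.4 (on this read-out higher numbers stand for higher lipophilicity and lower numbers for lower lipophilicity), compound 2 gives 3.62. Compound 3 gives 3.5, a number that lies within the scatter of that of compound 2, and compound 1 gives 2.75, a number beyond the scatter below it. Compound 4, `CC(C)CN(c1ccccc1F)S(=O)(=O)c1ccc2c(c1)C(=O)CC(C1CCOCC1)O2`, has not yet been measured in this assay. It differs from compound 2 in one place: hydrogen in place of fluoro on an aromatic carbon. Among the measured compounds shown here, no step between two measured compounds that differ in this way is at hand. The loss of one fluorine is expected to lower the number only slightly, a step of a number 0.17 log units lower from compound 2 to compound 4 (within the scatter), most likely within the scatter. Compound 4 is therefore estimated at 3.45, with a range from 3.1 to 3.8.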

Compound 4, distribution coefficient: 3.44
For compound 4 the middle estimate is 0.01 log units above the measured one; measured number inside the range.
By their numbers in this assay, from the lowest: compound 1; then compounds 4, 3 and 2 (each within the scatter of the next).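

In this assay the exchange of 2,4-difluorophenyl for 2-fluorophenyl gives a number 0.18 log units lower from compound 2 to compound 4 (within the scatter) and so shows that, at this position para to a large group, hydrogen in place of fluoro leaves the read-out within the scatter. The earlier compounds shown here differ in more than one place and could not show this single change on its own. Nothing at hand explains the size of this step.

The compounds shown leave open whether chloro, methoxy or an amine at this position would also stay within the scatter. They also leave open what replacing the remaining fluoro group with hydrogen would do.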